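Ester Variants of One Core Against MCF7 Growth

The source may report more compounds than this note shows. Statements on the series, on what has been measured and on what is new or still open speak of the compounds shown alone.

Measured compounds:
compound 1 `CC1=C(C(=O)OCc2ccccc2)C(c2ccc(Cl)cc2Cl)NC(=O)N1CCCC(=O)OCc1ccccc1` gives > 100000 nM in an ADME assay on MCF7 cells (Homo sapiens) for cytotoxicity, read by CellTiter-Glo, with a stated time of 24 h; on this read-out lower numbers stand for stronger inhibition of growth and higher numbers for weaker inhibition of growth
compound 2 `CC1=C(C(=O)OCc2ccccc2)C(c2ccc(Cl)cc2Cl)NC(=O)N1CCCCC(=O)O` gives > 100000 nM in this assay
compound 3 `CC1=C(C(=O)OCc2ccccc2)C(c2ccc(Cl)cc2Cl)NC(=O)N1CCCC(=O)OCc1ccccn1` gives > 100000 nM in this assay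

Each of these three values is a limit of this assay and not a number. Compound 2 therefore stands where the other two stand, at the limit of > 100000 nM in this assay, at which 3 of the 3 values shown sit, and no order among the three compounds can be read.

Compound 4 `CC1=C(C(=O)OCc2ccccc2)C(c2ccc(Cl)cc2Cl)NC(=O)N1CCCC(=O)OCC1CC1` is not yet measured. It differs from compound 2 as follows: cyclopropylmethoxycarbonyl in place of carboxymethyl on a saturated chain carbon, three bonds along the chain from an amide-type nitrogen in a ring.

Among the compounds with values here, two measured steps touch the same place on the chain. The change from compound 2 to compound 3 gives a step that the two limits leave unreadable from compound 2 to compound 3, and the change from compound 1 to compound 2 gives a step that the two limits leave unreadable from compound 1 to compound 2. Neither can be sized, since both partners sit at the limit, so they show only that replacing the carboxymethyl by an ester, or the reverse, has not brought any compound within the range of this assay.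

On that basis compound 4 is expected to remain at the limit, with the step that the limit leaves unreadable from compound 2 to compound 4 estimated as no readable change. Compound 4 is estimated at 150000 nM, in the range 60000 nM to 600000 nM.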

Compound 4, concentration for 50% growth inhibition: > 100000 nM
Compound 4 ended at the assay's limit (the forecaster's own chance of this, stated with the estimate: 85%); the middle value lies beyond the limit too.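

In this assay compound 4 gives > 100000 nM as a limit and not a number. Within the data shown here, no step between compound 4 and compound 1, compound 2 or compound 3 can be read, and all four compounds stand together: the limit of > 100000 nM in this assay, at which 4 of the 4 values shown sit. The compounds shown leave open how they rank beyond that limit and whether any change to the shared core would bring growth inhibition within the range of this assay at all.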